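Working notes: replacing ethoxycarbonyl in compound 3

This account rests on a few compounds, and the source may have more. Where it says the series, first, only, none or still open, it means among the compounds named here.

Measured values (a functional assay on NALM-6 cells (Homo sapiens) for cytotoxicity, with a stated time of 72 h; on this read-out higher numbers stand for an effect only at larger amounts of compound and lower numbers for an effect already at smaller amounts)
- compound 1 `C=C[C@@](C)(/C=C/c1ccc(O)cc1)CC/C=C(C)/C=N/N` gives > 43400 nM
- compound 2 `C=C[C@@](C)(/C=C/c1ccc(O)cc1)CC/C=C(\C)C=O` gives 12600 nM
- compound 3 `C=C[C@@](C)(/C=C/c1ccc(O)c(/C=C/C(=O)OCC)c1)CCC=C(C)C` gives 20900 nM
- compound 4 `C=C[C@@](C)(/C=C/c1ccc(O)c(/C=C/c2ccc(Cl)cc2)c1)CCC=C(C)C` is not yet measured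

For compound 1 the value > 43400 nM is a limit. Compound 3 at 20900 nM and compound 2 at 12600 nM lie within the scatter of each other. The next change is 4-chlorophenyl in place of ethoxycarbonyl, on a double-bonded chain carbon bound to a double-bonded chain carbon (4-chlorophenyl in place of ethoxycarbonyl on a double-bonded chain carbon bound to a double-bonded chain carbon). Among the compounds with values here, the one measured step (an at least 3.4-fold lower number from compound 1 to compound 2 (0.53 log units; beyond the scatter)) is beyond the scatter but concerns other groups, so it gives no size for this exchange. The expectation therefore starts from compound 3 (20900 nM) and foresees no clear move in either direction. In this assay the expected step (a 1.2-fold lower number from compound 3 to compound 4 (0.06 log units; within the scatter)) stays within the scatter. For compound 4 the estimated value is 18000 nM with an expected range of 6000 nM to 45000 nM in this estimate.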

Compound 4, half-maximal effective concentration: > 43400 nM
Compound 4: no number, only a limit; the forecaster's own chance of this, stated with the estimate: 20%; middle value at least 2.4-fold (0.38 log units) away from the limit.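

In this assay, within the data shown here, 4-chlorophenyl in place of ethoxycarbonyl gives the only step at this position, an at least 2.0-fold higher number from compound 3 to compound 4 (0.31 log units; beyond the scatter). Compound 4 gives > 43400 nM, which is a limit and not a number. This place therefore responds to the group it carries, though the full size of the step stays unknown: the limit of > 43400 nM in this assay, at which 2 of the 4 values shown sit.

Open, going by these compounds, is whether the departure of ethoxycarbonyl or the entry of 4-chlorophenyl accounts for the step. Also open, on these data alone, is how an amine or a carboxylic acid at this place would compare with compound 3.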